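The source may hold more compounds than are shown below. What is called first, only, known or untested is meant among the compounds shown, and "the series" means these compounds.

In a functional assay on HCT-116 cells (Homo sapiens) for inhibition, read by MTT assay, with a stated time of 96 h (on this read-out lower numbers stand for stronger inhibition of growth and higher numbers for weaker inhibition of growth), compound 1 (`CC(C)C(=O)SCCCCCCNC(=O)c1cc(-c2ccncc2)n[nH]1`) gives 22700 nM while compound 2 (`C=CCOC(=O)SCCCCCCNC(=O)c1cc(-c2ccncc2)n[nH]1`) gives 32900 nM and compound 3 (`CCCCCCCC/C=C\CCCCCCCC(=O)SCCCCCCNC(=O)c1cc(-c2ccncc2)n[nH]1`) gives 39300 nM on the same read-out. Compound 2 thus stands within the scatter of both compound 1 and compound 3. The next structure, compound 4 (`CC(=O)SCCCCCCNC(=O)c1cc(-c2ccncc2)n[nH]1`), differs from compound 2 by methyl in place of allyloxy on a carbonyl carbon and so carries methyl in place of allyloxy on a carbonyl carbon. Among the compounds with values here, the one measured step at this place, with allyloxy in place of isopropyl, is a 1.4-fold higher number from compound 1 to compound 2 (0.16 log units; within the scatter) and stays within the scatter. Compound 3 carries yet another group on that carbonyl carbon and also stays within the scatter of compound 2. Within the data shown here, no compound with methyl there has been measured, so the evidence is indirect and no shift beyond the scatter is expected. The estimated change is a 1.1-fold lower number from compound 2 to compound 4 (0.04 log units; within the scatter) and would be too small to read as a real difference. For compound 4 the expected value in this assay is 30000 nM with an estimated range from 15000 nM to 55000 nM around it.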

Compound 4, concentration for 50% growth inhibition: 41100 nM
Compound 4: the middle estimate sits 1.4-fold (0.14 log units) below what was measured, within the range that was stated.
By their numbers in this assay, from the lowest: compounds 1, 2, 3 and 4 (each within the scatter of the next).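

With allyloxy on the carbonyl carbon replaced by methyl, this assay shows a 1.2-fold higher number from compound 2 to compound 4 (0.10 log units; within the scatter), and with isopropyl replaced by methyl it shows a 1.8-fold higher number from compound 1 to compound 4 (0.26 log units; within the scatter). Methyl, with 1 heavy atom against the 4 heavy atoms of allyloxy and without its double bond, therefore stays within the scatter of both groups, so this position tolerates a group of only 1 heavy atom on this read-out without a shift that can be read as real. No measurement at hand bears on why these numbers stay so close.

On these data alone, how an amine or a phenyl group on that carbonyl carbon would read in this assay remains open. As far as these compounds go, the sulfur on the carbonyl carbon is the same in all four compounds, so the effect of an oxygen in its place also remains open.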